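The compounds below may be only part of what the source reports. "The series", "measured", "known", "first", "only" and "open" are said of these compounds alone.

In a functional assay on MGC-803 cells (Homo sapiens) for antiproliferative activity, read by MTT assay, with a stated time of 72 h (a higher number here means a weaker inhibitor, a lower number a stronger inhibitor), compound 2 (`O=C(N/N=C/c1ccccc1O)c1cccc(S(=O)(=O)N2CCOCC2)c1`) gives 25300 nM and compound 1 (`C/C(=N\NC(=O)c1cccc(S(=O)(=O)N2CCOCC2)c1)c1cc(Br)ccc1O`) gives 18000 nM and these two values lie within the scatter of each other. In compound 3 (`O=C(N/N=C/c1cc(Br)cc(Br)c1O)c1cccc(S(=O)(=O)N2CCOCC2)c1`), 3,5-dibromo-2-hydroxyphenyl stands in place of 2-hydroxyphenyl on a carbon with a double bond to nitrogen (3,5-dibromo-2-hydroxyphenyl in place of 2-hydroxyphenyl on a carbon with a double bond to nitrogen). A modest step toward a lower number is expected, estimated as a 2.5-fold lower number from compound 2 to compound 3 (0.40 log units; beyond the scatter) in this assay overall. The support is thin: compound 1 also carries bromine, and its 18000 nM lies within the scatter of compound 2. For compound 3 the estimated value is 10000 nM (expected range 3000 nM to 28000 nM).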

Compound 3, half-maximal inhibitory concentration: 17800 nM
Beside the measured number, compound 3's estimate is 1.8-fold (0.25 log units) below it; measured number inside the range.
By their numbers in this assay, from the lowest: compounds 3, 1 and 2 (each within the scatter of the next).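

In this assay the first single-place comparison reads a 1.4-fold lower number from compound 2 to compound 3 (0.15 log units; within the scatter) for 3,5-dibromo-2-hydroxyphenyl in place of 2-hydroxyphenyl on a carbon with a double bond to nitrogen. At this position, then, the two bromine atoms leave compound 3 within the scatter of compound 2, so the bromine seen earlier in compound 1 now has a direct comparison. Nothing available explains this result. Going by these compounds, whether a methoxy group or an amine in place of the bromine atoms would give a step beyond the scatter stays open.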